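Swapping a Formyl Group for 1-Methylethenyl on a Shared Core

The source may report more compounds than this note shows. Statements on the series, on what has been measured and on what is new or still open speak of the compounds shown alone.

Compound 1 `CC(Oc1ccccc1C=O)C1=NCCN1` is measured in an assay on CHO cells for displacement of a labelled ligand from Alpha-2C adrenergic receptor (Homo sapiens) (on this read-out higher numbers stand for weaker inhibition and lower numbers for stronger inhibition), where compound 1 gives 8710 nM, the highest of the three numbers here. Compound 2 `CC(Oc1ccccc1S(C)(=O)=O)C1=NCCN1` gives 3800 nM, and compound 3 `CCOc1ccccc1OC(C)C1=NCCN1` gives 759 nM. Both changes made to compound 1 lowered the number: a 2.3-fold lower number from compound 1 to compound 2 (0.36 log units; beyond the scatter), and an 11-fold lower number from compound 1 to compound 3 (1.06 log units; beyond the scatter). Compound 4 `C=C(C)c1ccccc1OC(C)C1=NCCN1` carries a further change at the same aromatic carbon: 1-methylethenyl in place of formyl on an aromatic carbon. The two measured steps from compound 1 both point toward lower numbers, with the ethoxy replacement giving the large one, so a downward step of modest to large size is expected, a 5.8-fold lower number from compound 1 to compound 4 (0.76 log units; beyond the scatter). On that basis compound 4 is estimated at 1500 nM, within a range from 400 nM to 5000 nM.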

Compound 4, inhibition constant: 603 nM
Estimate against measurement, compound 4: 2.5-fold (0.40 log units) above; measured number inside the range.
By their numbers in this assay, from the lowest: compounds 4 and 3 (each within the scatter of the next); then compound 2; then compound 1.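

1-Methylethenyl has no hydrogen-bond acceptor, yet it matches ethoxy, with a 1.3-fold lower number from compound 3 to compound 4 (0.10 log units; within the scatter), so an acceptor in the group at this aromatic carbon is not needed to reach this level. Formyl also has one double bond outside aromatic rings, yet replacing it gives a 14-fold lower number from compound 1 to compound 4 (1.16 log units; beyond the scatter), so such a double bond does not by itself set the number. Methylsulfonyl also falls behind, with a 6.3-fold lower number from compound 2 to compound 4 (0.80 log units; beyond the scatter).

No available evidence explains these differences. On these data alone, whether an amine or a longer carbon chain at this aromatic carbon would keep the number this low remains open.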